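Methoxy to Nitro: a Repeated Change and Its Expected Effect

The source may report more compounds than this note shows. Statements on the series, on what has been measured and on what is new or still open speak of the compounds shown alone.

Of the compounds shown here, three have been measured in an ADME assay on HEK-293T cells (Homo sapiens) for inhibition, read by CCK-8 assay, with a stated time of 48 h, tested at 20 uM; on this read-out lower numbers stand for less inhibition of growth and higher numbers for more inhibition of growth at the one concentration tested. Compound 1 `COc1ccc(Cc2nnc(NC(=O)/C(C#N)=C/c3ccccc3OS(=O)(=O)c3ccc(OC)cc3)s2)cc1` gives 30%. Compound 2 `COc1ccc(Cc2nnc(NC(=O)/C(C#N)=C/c3ccccc3OS(=O)(=O)c3ccc([N+](=O)[O-])cc3)s2)cc1` differs from it by nitro in place of methoxy on an aromatic carbon, and in this assay compound 2 gives 17%, so that a number 13 percentage points lower from compound 1 to compound 2 (beyond the scatter). Compound 3 `COc1ccc(S(=O)(=O)Oc2ccccc2/C=C(\C#N)C(=O)Nc2nnc(Cc3cccc(F)c3)s2)cc1` differs from compound 1 elsewhere in the molecule, by 3-fluorophenyl in place of 4-methoxyphenyl on a saturated chain carbon bound to an aromatic carbon, and in this assay compound 3 gives 29%; here a number 1 percentage points lower from compound 1 to compound 3 (within the scatter), so the two values cannot be told apart.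

Compound 4 `N#C/C(=C\c1ccccc1OS(=O)(=O)c1ccc([N+](=O)[O-])cc1)C(=O)Nc1nnc(Cc2cccc(F)c2)s1` has not yet been measured. It stands to compound 3 as compound 2 stands to compound 1: nitro in place of methoxy on an aromatic carbon. The place of the change is described in the same words for both pairs, so this is the same change, now made on the core of compound 3 rather than on the core of compound 1. The expected step is a number 12 percentage points lower from compound 3 to compound 4 (beyond the scatter), resting on the earlier a number 13 percentage points lower from compound 1 to compound 2 (beyond the scatter). Compound 4 is therefore estimated at 17%, with a plausible range from 7% to 27%. A single prior example gives limited confidence, so the range is kept wide.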

Compound 4, percent growth inhibition at one concentration: "not toxic" (no number reported)
Nothing numeric was reported for compound 4; no gap can be computed for the estimate.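

In this assay, for the compounds shown here, compound 4 is reported only as "not toxic", with no number, so no step from compound 3 to compound 4 can be read. Nothing else shown helps to explain this result. Still open, from the compounds shown here alone, is whether nitro in place of methoxy on the core of compound 3 repeats the earlier step, a number 13 percentage points lower from compound 1 to compound 2 (beyond the scatter).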